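Methoxy to hydroxy on the aryl of compound 2

This account rests on a few compounds, and the source may have more. Where it says the series, first, only, none or still open, it means among the compounds named here.

Two members of the series have numbers in a functional assay on A498 cells (Homo sapiens) for inhibition, read by sulforhodamine B assay, with a stated time of 48 h; a lower number here means a stronger inhibitor of growth, a higher number a weaker inhibitor of growth. Compound 1 `Cc1cc(O)cc(-c2nn(CC#N)cc2-c2ccnc(-c3ccc(Oc4ccccc4)cc3)c2)c1` gives 3870 nM. Compound 2 `COc1cc(C)cc(-c2nn(CC#N)cc2-c2ccnc(-c3ccc(N(C)C)cc3)c2)c1` gives 246 nM, the lower of the two, and the gap between compound 1 and compound 2 lies beyond the scatter; the two differ in more than one place, so no single step can be read from them. Compound 3 `Cc1cc(O)cc(-c2nn(CC#N)cc2-c2ccnc(-c3ccc(N(C)C)cc3)c2)c1` carries the change (hydrogen in place of methyl on an oxygen on an aromatic ring), hydrogen in place of methyl on an oxygen on an aromatic ring. Among the measured compounds shown here, no measured pair isolates this change. A small step is expected for compound 3 in this assay, a 1.6-fold higher number from compound 2 to compound 3 (0.21 log units; within the scatter), in either direction or none beyond the scatter, with compound 3 estimated at 400 nM, between 120 nM and 1500 nM.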

Compound 3, concentration for 50% growth inhibition: 3030 nM
For compound 3 the middle estimate is 7.6-fold (0.88 log units) below the measured one, and the stated range ends below it.
By their numbers in this assay, from the lowest: compound 2; then compounds 3 and 1 (each within the scatter of the next).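

On the oxygen on an aromatic ring, hydroxy does not stand in for methoxy in this assay: with dimethylamino held constant, hydrogen in place of methyl is a large step toward weaker growth inhibition (a 12-fold higher number from compound 2 to compound 3 (1.09 log units; beyond the scatter)). With hydroxy held constant, dimethylamino in place of phenoxy stays within the scatter (a 1.3-fold lower number from compound 1 to compound 3 (0.11 log units; within the scatter)), so this pair separates neither compound from the other. Nothing available explains the methyl-to-hydrogen step. Open, on these data alone, is whether ethoxy or a longer alkoxy chain on that oxygen keeps the number of compound 2, and whether phenoxy with methoxy on the aryl does the same.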